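Swapping the dichlorobenzyl arm on a shared diamine core

The source may hold more compounds than are shown below. What is called first, only, known or untested is meant among the compounds shown, and "the series" means these compounds.

Compound 1, `Nc1cc(N)c2nc(-c3ccccc3)c(NCc3ccc(Cl)c(Cl)c3)nc2c1`, gives < 100000 nM in a functional assay on SW-620 cells (Homo sapiens) for inhibition, read by sulforhodamine B assay, with a stated time of 48 h; on this read-out higher numbers stand for lower toxicity in this test and lower numbers for higher toxicity in this test.
Compound 2, `CCOC(=O)[C@H](CCC(=O)O)NC(=O)c1ccc(Sc2nc3cc(N)cc(N)c3nc2-c2ccccc2)cc1`, gives < 100000 nM in this assay.
Compound 3, `COc1cc(CNc2nc3cc(N)cc(N)c3nc2-c2ccccc2)cc(OC)c1OC`, gives < 50200 nM in this assay.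

Every value shown is a limit of the assay and not a number. Compound 1 stands at such a limit, shared by one other compound (the limit of < 100000 nM in this assay, at which 2 of the 3 values shown sit). Compound 3 sits at a second limit (the limit of < 50200 nM in this assay, at which 1 of the 3 values shown sits). Compound 4, `Nc1cc(N)c2nc(-c3ccccc3)c(NCc3ccc(F)cc3)nc2c1`, differs from compound 1 in one place: 4-fluorophenyl in place of 3,4-dichlorophenyl on a saturated chain carbon bound to a nitrogen on an aromatic ring. Within the data shown here, no step between measured compounds exists, and limits alone give no size to read from. The step from compound 1 to compound 4 is therefore expected to be none beyond the scatter, a number no lower from compound 1 to compound 4 (the limit leaves the size open). Compound 4 is expected to give 100000 nM in this assay, between 30000 nM and 300000 nM, most probably again as a limit.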

Compound 4, concentration lethal to 50% of the cells: < 100000 nM
Compound 4 gave a limit, no number; the forecaster's own chance of this, stated with the estimate: 80%; the middle value sits exactly at the limit.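

Compound 1 and compound 4 both give limits of the assay and not numbers, and no step can be read between them. The compounds shown leave open what actual value either compound reaches in this assay.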